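This account rests on a few compounds, and the source may have more. Where it says the series, first, only, none or still open, it means among the compounds named here.

Compound 1 `Cn1c(-c2ccc(NC(=O)CSc3nc4cc(Cl)ccc4o3)cc2)nc(-c2ccccc2)c1-c1ccccc1`: in a functional assay on HT-29 cells (Homo sapiens) for cytotoxicity, read by MTT assay, with a stated time of 24 h, tested at 16 ug/mL (a lower number here means a weaker effect, a higher number a stronger effect of the compound at the concentration tested), compound 1 gives 42.5%.
Compound 2 `CCN1CCN(CC(=O)Nc2ccc(-c3nc(-c4ccccc4)c(-c4ccccc4)n3C)cc2)CC1`: in this assay compound 2 gives 28.4%.

Going by the values given here, compound 2 stands lowest of these two numbers; its one step, a number 14.1 percentage points lower from compound 1 to compound 2 (beyond the scatter), exchanged the whole group on the chain carbon. Compound 3 `CN(C)/C=C/N1CCN(CC(=O)Nc2ccc(-c3nc(-c4ccccc4)c(-c4ccccc4)n3C)cc2)CC1` differs from compound 2 only at the ring nitrogen: 2-(dimethylamino)ethenyl in place of ethyl on an amine nitrogen in a ring. No measured step touches this ring nitrogen, so nothing shown argues for a move in either direction, and the step of a number 0.4 percentage points lower from compound 2 to compound 3 (within the scatter) is expected to stay within the scatter. Compound 3 is therefore estimated at 28%, in the range 15% to 42%.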

Compound 3, a percentage reported as activity, at one concentration (the size of the read-out at that concentration, not a potency): 28.2%
Estimate against measurement, compound 3: 0.2 percentage points below; low and high end bracket the measured number.
By their numbers in this assay, from the lowest: compounds 3 and 2 (each within the scatter of the next); then compound 1.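

In this assay, the larger 2-(dimethylamino)ethenyl group on the amine nitrogen in the ring gives a number 0.2 percentage points lower from compound 2 to compound 3 (within the scatter), so adding a nitrogen and a double bond to this substituent leaves the read-out unchanged within the scatter. Replacing (5-chloro-1,3-benzoxazol-2-yl)sulfanyl with this second piperazine group gives a number 14.3 percentage points lower from compound 1 to compound 3 (beyond the scatter), so the gap seen with 4-ethylpiperazin-1-yl holds for both piperazine groups. Nothing measured explains either step. On these data alone, whether this nitrogen tolerates every change remains open: a bare hydrogen, a carboxylic acid on a longer chain, or an aromatic ring there could still shift the number.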